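Shrinking the Saturated Side Chain on the Amide

The source may report more compounds than this note shows. Statements on the series, on what has been measured and on what is new or still open speak of the compounds shown alone.

Among the compounds with values here, compound 1 `O=C(CC1CCCCC1)N1CCN(c2nc(=O)c3cc(C(F)(F)F)cc([N+](=O)[O-])c3s2)CC1` stands lowest of the three numbers measured so far. In a physicochemical assay for solubility, read by HPLC (on this read-out higher numbers stand for higher solubility and lower numbers for lower solubility), compound 1 gives 0.12 ug/mL. Compound 2 `O=C(c1cccc(F)c1)N1CCN(c2nc(=O)c3cc(C(F)(F)F)cc([N+](=O)[O-])c3s2)CC1` carries 3-fluorophenyl in place of cyclohexylmethyl on a carbonyl carbon, and in this assay compound 2 gives 0.2 ug/mL; the step is a 1.7-fold higher number from compound 1 to compound 2 (0.22 log units; within the scatter). Compound 3 `CC(C)CC(=O)N1CCN(c2nc(=O)c3cc(C(F)(F)F)cc([N+](=O)[O-])c3s2)CC1` carries isopropyl in place of cyclohexyl on a saturated chain carbon bound to a carbonyl carbon, and in this assay compound 3 gives 66.3 ug/mL, a change of a 550-fold higher number from compound 1 to compound 3 (2.74 log units; beyond the scatter). The same move appears again as a 330-fold higher number from compound 2 to compound 3 (2.52 log units; beyond the scatter).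

Compound 4 `O=C(C1CCC1)N1CCN(c2nc(=O)c3cc(C(F)(F)F)cc([N+](=O)[O-])c3s2)CC1` has not yet been measured. Its change from compound 1 is cyclobutyl in place of cyclohexylmethyl on a carbonyl carbon. The step that bears on it most is a 550-fold higher number from compound 1 to compound 3 (2.74 log units; beyond the scatter), where the saturated group on the carbonyl also lost the same count of heavy atoms, and that step was large. The step of a 1.7-fold higher number from compound 1 to compound 2 (0.22 log units; within the scatter), which exchanged one group for another of similar size, moved nothing beyond the scatter. A large rise is therefore expected for compound 4. Within the data shown here, no measured step shows a four-membered ring in this place, so the estimate is kept somewhat below compound 3: compound 4 is estimated at 20 ug/mL, within a range from 4 ug/mL to 80 ug/mL, an expected step of a 170-fold higher number from compound 1 to compound 4 (2.22 log units; beyond the scatter).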

Compound 4, solubility: 39.3 ug/mL
Estimate against measurement, compound 4: 2.0-fold (0.29 log units) below, and the stated range covers the measured number.
By their numbers in this assay, from the lowest: compounds 1 and 2 (each within the scatter of the next); then compounds 4 and 3 (each within the scatter of the next).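

In this assay the large rise on leaving cyclohexylmethyl (a 330-fold higher number from compound 1 to compound 4 (2.52 log units; beyond the scatter)) also appears with cyclobutyl on the carbonyl carbon, so the jump seen with compound 3 does not need an open chain and also occurs with a small carbon ring. Set against the isobutyl group of compound 3, the ring makes no difference beyond the scatter (a 1.7-fold lower number from compound 3 to compound 4 (0.23 log units; within the scatter)), while the gap to the aromatic group stays wide (a 200-fold higher number from compound 2 to compound 4 (2.29 log units; beyond the scatter)). Among these four compounds, those with isobutyl and cyclobutyl therefore sit together, far from those with cyclohexylmethyl and 3-fluorophenyl, and nothing measured here explains that split.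

The compounds shown leave open how far the rise extends in either direction: cyclopropyl would test a smaller ring, and cyclopentyl or cyclohexyl would help to show where between cyclobutyl and cyclohexylmethyl the numbers fall. They also leave open what a saturated ring containing oxygen, such as tetrahydropyranyl, or a chain ending in an amine or a carboxylic acid would give on the same carbonyl carbon.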